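Working notes: replacing the 3-hydroxyphenyl group of compound 2

The source may report more compounds than this note shows. Statements on the series, on what has been measured and on what is new or still open speak of the compounds shown alone.

Measured in an ADME assay on HEL cells (Homo sapiens) for cytotoxicity; on this read-out lower numbers stand for higher toxicity in this test and higher numbers for lower toxicity in this test:
- compound 1 `O=C(COc1cccc2ccccc12)N/N=C/c1ccc(O)cc1`: 60.6 ug/mL
- compound 2 `O=C(COc1cccc2ccccc12)N/N=C/c1cccc(O)c1`: 62.7 ug/mL
- compound 3 `COc1ccc(/C=N/NC(=O)COc2cccc3ccccc23)cc1O`: 27.7 ug/mL

Compound 1 and compound 2 do not separate, the step being a 1.0-fold higher number from compound 1 to compound 2 (0.01 log units; within the scatter). Compound 3 lies lower, with a 2.3-fold lower number from compound 2 to compound 3 (0.35 log units; beyond the scatter), so compound 2 sits level with compound 1 and above compound 3 on these numbers.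

The next compound, compound 4 `O=C(COc1cccc2ccccc12)N/N=C/C=C/c1ccccc1`, carries 2-phenylethenyl in place of 3-hydroxyphenyl on a carbon with a double bond to nitrogen. Among the compounds with values here, no measured step makes this exact change, so the evidence is indirect. Replacing 4-hydroxyphenyl with 3-hydroxyphenyl gave a 1.0-fold higher number from compound 1 to compound 2 (0.01 log units; within the scatter), and adding methoxy gave a 2.3-fold lower number from compound 2 to compound 3 (0.35 log units; beyond the scatter). Across these three compounds, changes at this group have therefore produced nothing larger than a modest step. In this assay a small downward step is expected, probably within the scatter, with a modest fall or a rise both possible. Within the data shown here, the hydroxyl-bearing group itself is lost, and no measured compound shows what that does. The expected step is a 1.4-fold lower number from compound 2 to compound 4 (0.14 log units; within the scatter). Compound 4 is estimated at 45 ug/mL, with an expected range of 20 ug/mL to 95 ug/mL.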

Compound 4, half-maximal cytotoxic concentration: 100 ug/mL
Estimate against measurement, compound 4: 2.2-fold (0.35 log units) below, outside the stated range (above it).
By their numbers in this assay, from the lowest: compound 3; then compounds 1, 2 and 4 (each within the scatter of the next).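

In this assay, within the data shown here, this is the first change that removes the hydroxyl-bearing group from the carbon with a double bond to nitrogen, rather than moving the hydroxyl or adding methoxy, and the step stays within the scatter (a 1.6-fold higher number from compound 2 to compound 4 (0.20 log units; within the scatter)). The comparison with the 4-hydroxyphenyl analogue reads the same way (a 1.7-fold higher number from compound 1 to compound 4 (0.22 log units; within the scatter)), so neither hydroxyphenyl compound separates from the 2-phenylethenyl compound on this read-out. The exchange therefore takes the position from 1 hydrogen-bond donor and 1 hydrogen-bond acceptor to 0 of each and adds 1 double bond outside aromatic rings, with no step beyond the scatter, though nothing measured here explains this result.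

The compounds shown do not separate the loss of the hydroxyl from the arrival of the double bond, and an unsubstituted phenyl or a saturated 2-phenylethyl group at this place would bear directly on that question. On these data alone, how the position responds to an aminophenyl or carboxyphenyl group, or to a longer chain ending in phenyl, also remains open.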